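Chloro for methyl on the quinoline of compound 3

The compounds below may be only part of what the source reports. "The series", "measured", "known", "first", "only" and "open" are said of these compounds alone.

Measured so far in a functional assay on A549 cells (Homo sapiens) for inhibition, read by MTT assay, with a stated time of 72 h; on this read-out higher numbers stand for weaker inhibition and lower numbers for stronger inhibition:
- compound 1 `Cc1ccc(-c2cc(C(=O)N3CCC4(CC3)CC(=O)c3nn(C(C)(C)C)cc3O4)c3ccccc3n2)cc1`: 5300 nM
- compound 2 `CC(C)(C)n1cc2c(n1)C(=O)CC1(CCN(C(=O)c3cc(-c4ccc(Cl)cc4)nc4ccccc34)CC1)O2`: 2330 nM
- compound 3 `Cc1cc(C(=O)N2CCC3(CC2)CC(=O)c2nn(C(C)(C)C)cc2O3)c2ccccc2n1`: > 10000 nM

The value of compound 3 is a limit of this assay, not a number; it sits at the limit of > 10000 nM in this assay, at which 1 of the 3 values shown sits. Compound 1 and compound 2 share a core that carries a 4-methylphenyl or a 4-chlorophenyl on an aromatic carbon, and they differ only there: chloro in place of methyl on an aromatic carbon. That exchange gave a 2.3-fold lower number from compound 1 to compound 2 (0.36 log units; beyond the scatter). The core of compound 3 differs from the core of compound 1 in one place: methyl in place of 4-methylphenyl on an aromatic carbon; the step there was an at least 1.8-fold higher number from compound 1 to compound 3 (0.27 log units; that floor lies within the scatter), and from compound 2 it was an at least 4.2-fold higher number from compound 2 to compound 3 (0.63 log units; beyond the scatter).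

Compound 4 `CC(C)(C)n1cc2c(n1)C(=O)CC1(CCN(C(=O)c3cc(Cl)nc4ccccc34)CC1)O2` has not yet been measured in this assay. It differs from compound 3 by chloro in place of methyl on an aromatic carbon. The group that leaves and the group that enters are the same as between compound 1 and compound 2, so this is the same kind of change, but the place is not the same word for word: in compound 1 the methyl sits on a six-membered aromatic ring of carbon only, para to a large group, whereas in compound 3 it sits on a six-membered aromatic ring with 1 nitrogen, part of a fused or bridged system of two rings, next to the ring nitrogen.

Because compound 3 in this assay gives only > 10000 nM, the expected step to compound 4 is anchored loosely, and it is estimated as an at least 1.1-fold lower number from compound 3 to compound 4 (0.04 log units; that floor lies within the scatter), resting on the modest step seen between compound 1 and compound 2 of a 2.3-fold lower number from compound 1 to compound 2 (0.36 log units; beyond the scatter). Compound 4 is expected to give about 9000 nM in this assay, within a range of 3000 nM to 30000 nM.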

Compound 4, half-maximal inhibitory concentration: 7170 nM
The estimate for compound 4 lay 1.3-fold (0.10 log units) above the measured number; the measured number falls inside the stated range.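

In this assay, chloro in place of methyl can be compared on two cores: the same change on two cores in this assay, a 2.3-fold lower number (0.36 log units; beyond the scatter) from compound 1 to compound 2 and an at least 1.3-fold lower number (0.14 log units; that floor lies within the scatter) from compound 3 to compound 4; the limit leaves it open whether they differ. On the second of these cores, the change gives an at least 1.3-fold lower number from compound 3 to compound 4 (0.14 log units; that floor lies within the scatter). The value of compound 3 is a limit and not a number: the limit of > 10000 nM in this assay, at which 1 of the 4 values shown sits. The two steps therefore point the same way as far as they can be read, but this does not show that the change carries over to the core of compound 3 with the same size, or that it has any effect there beyond the usual scatter.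

The compounds leave open how much the aromatic group at this carbon matters, since replacing it with chloro gives a 3.1-fold higher number from compound 2 to compound 4 (0.49 log units; beyond the scatter), whereas the comparison with the other aromatic group gives a 1.4-fold higher number from compound 1 to compound 4 (0.13 log units; within the scatter). They also leave open whether a fluoro, a methoxy or an amine on the same aromatic carbon would fit alongside chloro and methyl, and whether the chloro-for-methyl step would hold on further cores.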